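Side-chain change from compound 2 to compound 3

The source may hold more compounds than are shown below. What is called first, only, known or untested is meant among the compounds shown, and "the series" means these compounds.

Compound 1 `CCCCNc1nc(NCc2ccco2)c2ccccc2n1` and compound 2 `CN(C)CCNc1nc(NCc2ccco2)c2ccccc2n1` share one core and differ only in the side chain. Going by the values given here, in a functional assay on DU-145 cells (Homo sapiens) for cytotoxicity, read by MTT assay, with a stated time of 2 days, tested at 10 uM (a higher number here means more inhibition at the concentration tested (going by the name of the read-out), a lower number less inhibition), compound 1 gives 89.9%, while compound 2 gives 20%, the lowest of the two numbers; the step of a number 69.9 percentage points lower from compound 1 to compound 2 (beyond the scatter) is the only measured step. Compound 3 `c1coc(CNc2nc(NCCCN3CCCC3)nc3ccccc23)c1` is not yet measured. Relative to compound 2 the change is (pyrrolidin-1-yl)methyl in place of dimethylamino on a saturated chain carbon, two bonds along the chain from a nitrogen on an aromatic ring. Among the compounds with values here, the one measured step does not repeat this change, and no step with a ring amine is known, so the expectation leans on compound 2 staying low at 20%. The step of a number 12 percentage points higher from compound 2 to compound 3 (beyond the scatter) is expected to be modest, more likely upward than downward, and possibly within the scatter. Compound 3 is therefore estimated at 32%, with a range from 8% to 62%.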

Compound 3, a percentage reported as inhibition, at one concentration (the size of the read-out at that concentration, not a potency): 40.1%
Compound 3: the middle estimate sits 8.1 percentage points below what was measured, within the range that was stated.
By their numbers in this assay, from the lowest: compound 2; then compound 3; then compound 1.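

In this assay, the exchange of dimethylamino for (pyrrolidin-1-yl)methyl on a saturated chain carbon gives a number 20.1 percentage points higher from compound 2 to compound 3 (beyond the scatter), so this place responds to the side-chain amine and its surroundings, not only to the presence of an amine. The ring-bearing side chain still falls short of the side chain of compound 1, with a number 49.8 percentage points lower from compound 1 to compound 3 (beyond the scatter), and both amine-bearing compounds, compound 2 and compound 3, stand lower than compound 1. Nothing available explains either step.

The exchange of 2-(dimethylamino)ethyl for 3-(pyrrolidin-1-yl)propyl alters chain length and amine together, so a 3-(dimethylamino)propyl or a 2-(pyrrolidin-1-yl)ethyl side chain would be needed to separate the two. From the compounds shown here alone, how a six-membered ring amine such as piperidine or morpholine would read in this assay also stays open.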